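Acetoxy in place of hydrogen: compound 2 to compound 3

This account rests on a few compounds, and the source may have more. Where it says the series, first, only, none or still open, it means among the compounds named here.

Values from a functional assay on HT-1080 cells (Homo sapiens) for cytotoxicity, read by sulforhodamine B assay, with a stated time of 48 h (on this read-out higher numbers stand for an effect only at larger amounts of compound and lower numbers for an effect already at smaller amounts), follow.
- Compound 1 `CCCC[C@@H](/C=C\[C@@H]1OC(=O)C[C@@H](OC)[C@@H]1O)OC(C)=O` gives > 20 ug/mL as a limit
- Compound 2 `CCCC[C@H](OC(C)=O)[C@@H](OC(C)=O)[C@H](OC(C)=O)[C@H]1CC=CC(=O)O1` gives 4.5 ug/mL as a number

Within the data shown here, compound 2 holds the only number in the set, the other entry being a limit. Compound 3 `CCCC[C@H](OC(C)=O)[C@@H](OC(C)=O)[C@H](OC(C)=O)[C@@H]1OC(=O)C=C[C@@H]1OC(C)=O` differs from compound 2 by acetoxy in place of hydrogen on a saturated ring carbon and so has acetoxy in place of hydrogen on a saturated ring carbon. Among the measured compounds shown here, no measured step in this assay sizes this change, so a shift beyond the scatter is not expected, with compound 2 at 4.5 ug/mL as the anchor. The expected step is a 1.1-fold lower number from compound 2 to compound 3 (0.05 log units; within the scatter) in size. Compound 3 is estimated at 4 ug/mL with 1.5 ug/mL to 14 ug/mL as the expected range.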

Compound 3, concentration for half-maximal effect: 8.4 ug/mL
Compound 3: the middle estimate sits 2.1-fold (0.32 log units) below what was measured; the measured number falls inside the stated range.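

In this assay acetoxy in place of hydrogen on a saturated ring carbon, next to the ring atom that bears a large group, gives a 1.9-fold higher number from compound 2 to compound 3 (0.27 log units; within the scatter) and is thus tolerated at this position. Among these compounds, this is the first step in the set that can be read, and it shows that this added group causes no shift beyond the scatter.

On these data alone, whether an amine or a longer acyl chain on the same ring carbon would behave alike stays open. Compound 1 stands as a limit, so steps to it cannot be read: the limit of > 20 ug/mL in this assay, at which 1 of the 3 values shown sits.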